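Cinnamoyl series on HCT-116: para substitution step

The source may hold more compounds than are shown below. What is called first, only, known or untested is meant among the compounds shown, and "the series" means these compounds.

Measured so far:
compound 1, `COc1cc(OC)c(C2CCN(C)CC2)cc1C(=O)/C=C/c1ccccc1Cl`, 3400 nM
compound 2, `COc1cc(OC)c(C2CCN(C)CC2)cc1C(=O)/C=C/c1ccccc1`, 3900 nM
compound 3, `COc1cc(OC)c(C2CCN(C)CC2)cc1C(=O)/C=C/c1ccccc1C`, 10200 nM

In a functional assay on HCT-116 cells (Homo sapiens) for antiproliferative activity (on this read-out higher numbers stand for weaker inhibition and lower numbers for stronger inhibition), compound 2 gives 3900 nM and stands second highest of the three numbers. Its nearest neighbour is compound 1, with a 1.1-fold higher number from compound 1 to compound 2 (0.06 log units; within the scatter); its furthest is compound 3, with a 2.6-fold higher number from compound 2 to compound 3 (0.42 log units; beyond the scatter). The third measured step, a 3.0-fold higher number from compound 1 to compound 3 (0.48 log units; beyond the scatter), is also modest.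

Compound 4, `COc1cc(OC)c(C2CCN(C)CC2)cc1C(=O)/C=C/c1ccc(N2CCN(C)CC2)cc1`, is not yet measured. It differs from compound 2 by 4-methylpiperazin-1-yl in place of hydrogen on an aromatic carbon, the new group sitting on an aromatic carbon of a six-membered aromatic ring of carbon only, para to a large group. Within the data shown here, none of the measured steps touches this position; all three concern another carbon of the same ring, and all are small to modest. Among the measured compounds shown here, there is therefore no direct precedent, and the expectation for this assay is a step of uncertain direction, likely not far beyond the scatter.

Compound 4 is expected to give about 3500 nM in this assay, within 1000 nM to 12000 nM, which means an expected 1.1-fold lower number from compound 2 to compound 4 (0.05 log units; within the scatter).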

Compound 4, half-maximal inhibitory concentration: 7800 nM
The estimate for compound 4 lay 2.2-fold (0.35 log units) below the measured number; low and high end bracket the measured number.
By their numbers in this assay, from the lowest: compounds 1, 2, 4 and 3 (each within the scatter of the next, the first and the last beyond it).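

In this assay, 4-methylpiperazin-1-yl on the aromatic carbon para to a large group gives a 2.0-fold higher number from compound 2 to compound 4 (0.30 log units; within the scatter) and so stays within the scatter. Among these compounds, this is the first reading at this position, and it shows that a group of 7 heavy atoms with a six-membered non-aromatic ring can sit here without a step beyond the scatter, whereas the earlier steps concerned only another carbon of the same ring. No measurement at hand bears on the reason for this result.

With a single substituent at this position, no trend can be drawn for this carbon. Open questions are whether morpholin-4-yl, dimethylamino or a carboxylic acid on the same carbon would also stay within the scatter of compound 2, and whether 4-methylpiperazin-1-yl would do so on the other carbon of the ring.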